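A few compounds are considered here, and "the series" means these few. Any claim that something is new, unique, unknown or untested is made for them only; others in the source may bear on it.

Compound 1 `COc1cc2cc(Oc3ccc(NC(=O)Nc4cccc(C(F)(F)F)c4)cc3)c(C)nc2cc1OC`: 9930 nM in a functional assay on SK-MEL-2 cells (Homo sapiens) for inhibition, read by sulforhodamine B assay, with a stated time of 48 h; a lower number here means that less compound is tolerated, a higher number that more compound is tolerated
Compound 2 `COc1cc2cc(Oc3ccc(NC(=O)Nc4ccc(Cl)c(C(F)(F)F)c4)cc3)c(C)nc2cc1OC`: 11000 nM in this assay

Only these two compounds have been measured in this assay. Compound 1 gives 9930 nM and compound 2 gives 11000 nM. Going by the values given here, the single step between them, a 1.1-fold higher number from compound 1 to compound 2 (0.04 log units; within the scatter), is chloro in place of hydrogen on an aromatic carbon and leaves the two compounds within the scatter of each other, so compound 2 does not stand apart from compound 1 on these numbers.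

Compound 3 `COc1cc2cc(Oc3ccc(NC(=O)Nc4ccc(Cl)c(Cl)c4)cc3)c(C)nc2cc1OC` has not been measured. It differs from compound 2 by chloro in place of trifluoromethyl on an aromatic carbon. Among the compounds with values here, no measured step exchanges trifluoromethyl for chloro; the only step available, a 1.1-fold higher number from compound 1 to compound 2 (0.04 log units; within the scatter), concerns a chloro entering on an aromatic carbon and was itself within the scatter, so it bears on the new change only loosely. With nothing beyond the scatter among the measured changes, the expectation is a step of a 1.1-fold lower number from compound 2 to compound 3 (0.04 log units; within the scatter), in no particular direction beyond the scatter. Compound 3 is therefore estimated at 10000 nM, with a range from 4000 nM to 25000 nM.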

Compound 3, concentration lethal to 50% of the cells: 20600 nM
Compound 3: middle estimate off by 2.1-fold (0.31 log units), on the low side, and the stated range covers the measured number.
By their numbers in this assay, from the lowest: compounds 1, 2 and 3 (each within the scatter of the next, the first and the last beyond it).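

In this assay, exchanging trifluoromethyl for chloro on an aromatic carbon, ortho to a chloro group and meta to a large group, gives a 1.9-fold higher number from compound 2 to compound 3 (0.27 log units; within the scatter), so replacing this group of four heavy atoms with a single chlorine does not separate compound 3 from compound 2. Read across the whole aryl group, however, the series now holds its first step beyond the scatter, a modest one, as 3,4-dichlorophenyl in place of 3-(trifluoromethyl)phenyl on an amide-type nitrogen gives a 2.1-fold higher number from compound 1 to compound 3 (0.32 log units; beyond the scatter), while compound 2 remains within the scatter of both compound 1 and compound 3. Nothing available on these compounds accounts for either step.

The compounds shown leave open how a methoxy, a nitrile or an amine would read at this place in this assay, as only trifluoromethyl and chloro have stood there. They also leave open whether chloro in place of trifluoromethyl would read the same on a ring that carries no second chloro group.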